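The source may report more compounds than this note shows. Statements on the series, on what has been measured and on what is new or still open speak of the compounds shown alone.

In a functional assay on A549 cells (Homo sapiens) for cytotoxicity (a higher number here means that more compound is needed for the effect, a lower number that less compound is needed), compound 1 (`C#C/C=C\CCCCCCCCCCCCCC/C=C/CCCC/C=C/CCCCC#C[C@@H](O)C#CCCCCCC/C=C/[C@H](O)C#C`) gives 1.1 ug/mL and compound 2 (`C#C/C=C\CCCCCCCCCCCCCC/C=C/CCCC/C=C/CC/C=C/C#C[C@@H](O)C#CCCCCCC/C=C/[C@H](O)C#C`) gives 1.6 ug/mL as its measured value. Going by the values given here, these two numbers lie within the usual scatter of each other, so compound 1 stands level with the only other compound measured so far. Compound 3 (`C#C/C=C\CCCCCCCCCCCCCC/C=C/CCCC/C=C/CCCCC#C[C@@H](O)C#CCCCCCCCC[C@H](O)C#C`) has not yet been tested. Its structure departs from compound 1 in one place: a group of 6 heavy atoms (5 carbon, 1 oxygen; no ring) in place of a group of 6 heavy atoms (5 carbon, 1 oxygen; no ring), on a saturated chain carbon, six bonds along the chain from a triple-bonded carbon on a saturated chain carbon, six bonds along the chain from a triple-bonded carbon. The group that enters keeps the triple bond and the hydrogen-bond donor of the group that leaves, but it carries no double bond. Among the compounds with values here, no measured pair shows this change on its own, so the data offer no direct step for it. Within the data shown here, the close agreement of the two measured numbers is the only guide, and no shift beyond the scatter is expected in this assay for this change, perhaps only a slight drift towards a higher number. The estimated step is a 1.4-fold higher number from compound 1 to compound 3 (0.13 log units; within the scatter) and would stay within the scatter. For compound 3 the expected value is 1.5 ug/mL with an estimated range from 0.6 ug/mL to 4 ug/mL in this assay.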

Compound 3, concentration for half-maximal effect: 1.7 ug/mL
Compound 3: middle estimate off by 1.1-fold (0.05 log units), on the low side; measured number inside the range.
By their numbers in this assay, from the lowest: compounds 1, 2 and 3 (each within the scatter of the next).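

Going by these compounds alone, compound 3 gives the first direct reading of this change on a saturated chain carbon, six bonds along the chain from a triple-bonded carbon. In this assay the step is small (a 1.5-fold higher number from compound 1 to compound 3 (0.19 log units; within the scatter)), so the double bond of the group that leaves is not required for compound 3 to stand level with compound 1. The result also shows that this position tolerates at least one change of its group without a measurable shift in this read-out, although a single pair cannot show how general that is. Nothing at hand explains the result or says how the double bond bears on it.

The compounds shown leave open whether the hydroxyl and the triple bond that compound 1 and compound 3 share in this group matter for the read-out, since both are kept in the group that enters. They also leave open how a ketone or an amine in place of that hydroxyl, or a longer chain at this position, would read in this assay on the shared core.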